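Amide aryl variation on the bis-indole core: quinolinyl analogue

This account rests on a few compounds, and the source may have more. Where it says the series, first, only, none or still open, it means among the compounds named here.

Among the compounds with values here, compound 2 `CN1[C@@H]2c3[nH]c4ccccc4c3C[C@H]1[C@H](C#N)N1[C@@H](CNC(=O)c3cccc4c3CCCC4)c3[nH]c4ccccc4c3C[C@@H]21` gives the highest of the two numbers measured so far; in a functional assay on A2780 cells (Homo sapiens) for cytotoxicity, read by MTT assay, with a stated time of 72 h (a higher number here means a weaker inhibitor, a lower number a stronger inhibitor), compound 2 gives 810 nM. Its nearest neighbour is compound 1 `COc1ccc(C(=O)NC[C@H]2c3[nH]c4ccccc4c3C[C@H]3[C@H]4c5[nH]c6ccccc6c5C[C@@H]([C@H](C#N)N23)N4C)cc1`, which in this assay gives 320 nM; the step of a 2.5-fold higher number from compound 1 to compound 2 (0.40 log units; beyond the scatter) is beyond the scatter but modest. Compound 3 `CN1[C@@H]2c3[nH]c4ccccc4c3C[C@H]1[C@H](C#N)N1[C@@H](CNC(=O)c3ccc4ccccc4n3)c3[nH]c4ccccc4c3C[C@@H]21` differs from compound 2 by quinolin-2-yl in place of 1,2,3,4-tetrahydronaphthalen-5-yl on a carbonyl carbon. Within the data shown here, the only measured step in this position, a 2.5-fold higher number from compound 1 to compound 2 (0.40 log units; beyond the scatter), concerns a different exchange of the aryl group on the carbonyl and does not point to the quinolinyl case; it shows only that changing this aryl moves the number modestly. Among the measured compounds shown here, no step bears directly on the change to compound 3, so a step of no more than modest size in this assay, in either direction, is expected: a 1.4-fold lower number from compound 2 to compound 3 (0.13 log units; within the scatter). For compound 3 the value in this assay is estimated at 600 nM, within a range from 250 nM to 1600 nM.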

Compound 3, half-maximal inhibitory concentration: 60 nM
Estimate against measurement, compound 3: 10-fold (1.00 log units) above; the whole stated range lies above it.
By their numbers in this assay, from the lowest: compound 3; then compound 1; then compound 2.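

In this assay, the aryl group on the carbonyl carbon can move the number much further than the earlier pair showed: quinolin-2-yl in place of 1,2,3,4-tetrahydronaphthalen-5-yl gives a 14-fold lower number from compound 2 to compound 3 (1.13 log units; beyond the scatter), although the two groups have the same heavy-atom count. Against the 4-methoxyphenyl amide, quinolin-2-yl gives a 5.3-fold lower number from compound 1 to compound 3 (0.73 log units; beyond the scatter), so compound 3 has the lowest number of the three, with both steps beyond the scatter. Nothing available accounts for the size of this shift.

The compounds shown leave open whether the ring nitrogen of quinolin-2-yl or the second aromatic ring goes with the lower number. A naphthalen-2-yl amide would separate these two features, and a pyridin-2-yl amide would show whether the ring nitrogen alone is enough.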